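Chloro in Place of Trifluoromethyl on Compound 1

This account rests on a few compounds, and the source may have more. Where it says the series, first, only, none or still open, it means among the compounds named here.

Within the data shown here, compound 1 `Cc1ccc(N2CC(c3nc(-c4cccc(C(F)(F)F)c4)no3)CC2=O)cc1` is the only compound here with a measured number: in an in vitro functional assay on HEK293-A cells for positive allosteric modulation of metabotropic glutamate receptor 5 (Homo sapiens), read by FLIPR and calcium flux (a higher number here means that more compound is needed for the effect, a lower number that less compound is needed), compound 1 gives 3400 nM. Compound 2 `Cc1cccc(-c2noc(C3CC(=O)N(c4ccc(F)cc4)C3)n2)n1` gives only a limit of the assay, > 10000 nM, so no number stands beside it. That limit is the point at which one of the two values sits (the limit of > 10000 nM in this assay, at which 1 of the 2 values shown sits).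

Compound 3 `Cc1ccc(N2CC(c3nc(-c4cccc(Cl)c4)no3)CC2=O)cc1` differs from compound 1 by one change (chloro in place of trifluoromethyl on an aromatic carbon). Among the measured compounds shown here, no measured pair shows this kind of change, so the size of the step is open. The step of a 1.2-fold higher number from compound 1 to compound 3 (0.07 log units; within the scatter) is expected to be no larger than the usual scatter. The estimate for compound 3 is 4000 nM, between 1500 nM and 12000 nM.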

Compound 3, half-maximal effective concentration: 630 nM
Estimate against measurement, compound 3: 6.3-fold (0.80 log units) above; measured number below the stated range.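

Among these compounds, replacing trifluoromethyl with chloro on this aromatic carbon gives a 5.4-fold lower number from compound 1 to compound 3 (0.73 log units; beyond the scatter) in this assay, the first measured step at this position. It shows that the group on this carbon can change how much compound is needed, and that a single chlorine atom can do better here than the four heavy atoms of trifluoromethyl. Nothing measured here accounts for the size of this step.

From the compounds shown here alone, with only these two groups compared on this carbon, it remains open how a nitrile, a methoxy group or an amine would behave there.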